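Cytotoxicity limits across a cyclic sulfonate series

A few compounds are considered here, and "the series" means these few. Any claim that something is new, unique, unknown or untested is made for them only; others in the source may bear on it.

Compound 1 `CCC1(Cc2ccccc2)OS(=O)(=O)C=C1OCC(=O)OC` carries the shared core with a (methoxycarbonyl)methoxy group on the double-bonded ring carbon. In an ADME assay on HEL cells (Homo sapiens) for cytotoxicity, with a stated time of 3 days (a higher number here means that more compound is tolerated, a lower number that less compound is tolerated), compound 1 gives > 400000 nM, which is a limit of the assay and not a number. Compound 2 `CCC1(Cc2ccccc2)OS(=O)(=O)C=C1OCc1ccc(OC)cc1` gives >= 200000 nM in this assay, again a limit. Compound 3 `CCC1(Cc2ccccc2)OS(=O)(=O)C=C1OCc1ccc(C)cc1` gives >= 16000 nM in this assay, also a limit. With every value a limit, the steps a step that the two limits leave unreadable from compound 1 to compound 2, a step that the two limits leave unreadable from compound 1 to compound 3 and a step that the two limits leave unreadable from compound 2 to compound 3 cannot be read, so compound 1 stands at a limit with no measurable separation from the others (the limit of > 400000 nM in this assay, at which 1 of the 3 values shown sits, (the limit of >= 200000 nM in this assay, at which 1 of the 3 values shown sits), (the limit of >= 16000 nM in this assay, at which 1 of the 3 values shown sits)).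

Compound 4 `CCC1(Cc2ccccc2)OS(=O)(=O)C=C1NCc1ccccc1` differs from compound 1 in one place: benzylamino in place of (methoxycarbonyl)methoxy on a double-bonded ring carbon. Within the data shown here, the steps that bear on it exchange the methoxycarbonyl end of the same chain, and both are unreadable, so no size of step can be drawn from them; the three limits only set a band. Compound 4 is estimated at 100000 nM, within 16000 nM to 400000 nM. That estimate means an expected step of an at least 4.0-fold lower number from compound 1 to compound 4 (0.60 log units; beyond the scatter), and a further limit rather than a number is likely.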

Compound 4, minimum cytotoxic concentration: >= 80000 nM
Compound 4 ended at the assay's limit; the forecaster's own chance of this, stated with the estimate: 60%; the middle value lies beyond the limit too.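

Among these compounds, with compound 1 and compound 4 both standing at limits of the assay and not at numbers, the exchange of (methoxycarbonyl)methoxy for benzylamino gives no step that can be read. The compounds shown leave open whether this assay would give an actual number for any of the four, and so whether their groups differ at all.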